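A few compounds are considered here, and "the series" means these few. Any claim that something is new, unique, unknown or untested is made for them only; others in the source may bear on it.

In a functional assay on cells (leukaemia cell line, Homo sapiens) for inhibition, read by sulforhodamine B assay, with a stated time of 48 h (a lower number here means a stronger inhibitor of growth, a higher number a weaker inhibitor of growth), the measured compounds stand as follows:
- compound 1 `O=S(=O)(Nc1ccc(Cl)c(F)c1)c1ccc(-c2cnc(C3CC3)o2)cc1` gives 380 nM
- compound 2 `Cc1ccc(NS(=O)(=O)c2ccc(-c3cnc(C4CC4)o3)cc2)cc1C` gives 420 nM
- compound 3 `O=S(=O)(Nc1cc(F)cc(F)c1)c1ccc(-c2cnc(C3CC3)o2)cc1` gives 2140 nM

Compound 3 has the highest number of the three and is the weakest inhibitor of growth here. Compound 4 `O=S(=O)(Nc1ccc(I)c(Cl)c1)c1ccc(-c2cnc(C3CC3)o2)cc1` has 3-chloro-4-iodophenyl in place of 3,5-difluorophenyl on a sulfonamide nitrogen. The relevant steps are a 5.6-fold higher number from compound 1 to compound 3 (0.75 log units; beyond the scatter) and a 5.1-fold higher number from compound 2 to compound 3 (0.71 log units; beyond the scatter), both modest, while a 1.1-fold higher number from compound 1 to compound 2 (0.04 log units; within the scatter) shows no separation. Within the data shown here, by name, the entering group resembles 4-chloro-3-fluorophenyl and 3,4-dimethylphenyl, although no measured compound carries iodine. A modest step to a lower number is therefore expected in this assay. The expected step is a 5.4-fold lower number from compound 3 to compound 4 (0.73 log units; beyond the scatter) overall. Compound 4 is expected at 400 nM with an estimated range from 130 nM to 1200 nM as the upper end.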

Compound 4, concentration for 50% growth inhibition: 1010 nM
Compound 4: middle estimate off by 2.5-fold (0.40 log units), on the low side; the range from low to high includes it.
By their numbers in this assay, from the lowest: compounds 1 and 2 (each within the scatter of the next); then compound 4; then compound 3.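

In this assay 3-chloro-4-iodophenyl on a sulfonamide nitrogen gives a 2.1-fold lower number from compound 3 to compound 4 (0.33 log units; beyond the scatter) but does not reach the other two groups, with a 2.4-fold higher number from compound 2 to compound 4 (0.38 log units; beyond the scatter) and a 2.7-fold higher number from compound 1 to compound 4 (0.42 log units; beyond the scatter) as the remaining gaps. This place now shows three levels among the four compounds, with compound 4 alone in the middle, so the likeness by name to 4-chloro-3-fluorophenyl and 3,4-dimethylphenyl does not hold in the numbers. No measurement bears on why compound 4 stands there. Open, going by these compounds, is how an unsubstituted phenyl, or a phenyl carrying an amine or a carboxylic acid, would stand at this place.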